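Bromo for Fluoro on the Pendant Phenyl Ring

A few compounds are considered here, and "the series" means these few. Any claim that something is new, unique, unknown or untested is made for them only; others in the source may bear on it.

For the measured compounds named here, compound 2 `CC(C)(C)c1cc(NC(=O)Nc2cc(C(F)(F)F)cc(C(F)(F)F)c2)n(-c2ccc(F)cc2)n1` was examined in an assay on isolated protein for inhibition of serine/threonine-protein kinase 10 (Homo sapiens), read by thermal shift assay, tested at 10 uM (a lower number here means that the compound stabilises the target less, a higher number that the compound stabilises the target more against heat), where compound 2 gives -0.6 degrees C. Its only measured neighbour is compound 1 `Cc1ccc(-n2nc(C(C)(C)C)cc2NC(=O)Nc2cc(C(F)(F)F)cc(C(F)(F)F)c2)cc1`, which in this assay gives -0.5 degrees C; the single measured step, a number 0.10 degrees C lower from compound 1 to compound 2 (within the scatter), leaves the two compounds side by side, within the scatter of each other. Compound 2 thus stands level with compound 1 on the numbers shown, with neither stabilising the target beyond the scatter.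

The unmeasured compound 3 `CC(C)(C)c1cc(NC(=O)Nc2cc(C(F)(F)F)cc(C(F)(F)F)c2)n(-c2ccc(Br)cc2)n1` differs from compound 2 in one place: bromo in place of fluoro on an aromatic carbon. Going by the values given here, the one step that bears on this exchange is the swap at the same aromatic carbon, a number 0.10 degrees C lower from compound 1 to compound 2 (within the scatter), which stayed within the scatter. With no measured change at this position reaching beyond the scatter, compound 3 is expected to show no step beyond the scatter, a number 0.10 degrees C higher from compound 2 to compound 3 (within the scatter). The estimate for compound 3 in this assay is -0.5 degrees C, between -1.5 degrees C and 0.5 degrees C.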

Compound 3, shift of the target's melting temperature: -0.3 degrees C
Estimate against measurement, compound 3: 0.20 degrees C below; the measured number falls inside the stated range.
By their numbers in this assay, from the lowest: compounds 2, 1 and 3 (each within the scatter of the next).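

Bromo at this aromatic carbon, on the 4-bromophenyl group, gives a number 0.30 degrees C higher from compound 2 to compound 3 (within the scatter) in this assay when it replaces fluoro, and a number 0.20 degrees C higher from compound 1 to compound 3 (within the scatter) when it replaces methyl. Methyl, fluoro and bromo have now all been compared at this one carbon, and none of the three steps among compounds 1, 2 and 3 lies beyond the scatter, so this position has yet to show a step that can be told from the scatter in this assay. Nothing at hand gives a reason for this flat result.

On these data alone, it remains open whether an amine, a carboxylic acid or a methoxy group at this same carbon would produce a step beyond the scatter. As far as these compounds go, it is equally open whether replacing the tert-butyl group or either trifluoromethyl group would do so.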